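Carboxy for chloro on the aryl ketone of compound 3

A few compounds are considered here, and "the series" means these few. Any claim that something is new, unique, unknown or untested is made for them only; others in the source may bear on it.

Measured compounds:
compound 1, `CN(C)c1ccc(/C=C(\C(=O)c2ccc(C(=O)O)cc2)S(=O)(=O)Cc2ccc(Cl)cc2)cc1`: > 100000 nM
compound 2, `O=C(O)c1ccc(C(=O)/C(=C\c2ccc(Cl)c([N+](=O)[O-])c2)SCc2ccc(Cl)cc2)cc1`: 1000 nM
compound 3, `CN(C)c1ccc(/C=C(/SCc2ccc(Cl)cc2)C(=O)c2ccc(Cl)cc2)cc1`: > 100000 nM

In a functional assay on DU-145 cells (Homo sapiens) for inhibition, read by trypan blue exclusion, with a stated time of 96 h (a lower number here means a stronger inhibitor of growth, a higher number a weaker inhibitor of growth), compound 3 gives only a limit, > 100000 nM, not a number. Compound 1 likewise gives only a limit in this assay, > 100000 nM. Two of the three values thus sit at the limit of > 100000 nM in this assay, at which 2 of the 3 values shown sit. For the measured compounds named here, compound 2, the one member with a measured number, gives 1000 nM in this assay; it carries the carboxy group and the thioether, but differs from the others at the other aryl ring, so no single step to it is defined.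

Compound 4, `CN(C)c1ccc(/C=C(/SCc2ccc(Cl)cc2)C(=O)c2ccc(C(=O)O)cc2)cc1`, is compound 3 with one change: carboxy in place of chloro on an aromatic carbon. Going by the values given here, with compound 3 at a limit, no measured step bounds this change. Compound 1 shows that carboxy together with the dimethylamino aryl group reaches the same limit, though with a sulfone rather than a thioether. For compound 4 the step of a number no higher from compound 3 to compound 4 (the limit leaves the size open) is therefore expected to be small, most likely none beyond the scatter, with the value again ending at a limit. The estimate for compound 4 in this assay is 100000 nM, with a range from 20000 nM to 300000 nM.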

Compound 4, concentration for 50% growth inhibition: 1000 nM
Estimate against measurement, compound 4: 100-fold (2.00 log units) above; measured number outside the range, below it.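

In this assay, carboxy in place of chloro on the aromatic carbon gives an at least 100-fold lower number from compound 3 to compound 4 (2.00 log units; beyond the scatter), and (4-chlorobenzyl)sulfanyl in place of (4-chlorobenzyl)sulfonyl gives an at least 100-fold lower number from compound 1 to compound 4 (2.00 log units; beyond the scatter). Compound 3 and compound 1 each stand at a limit, so these two steps fix only a minimum size: the limit of > 100000 nM in this assay, at which 2 of the 4 values shown sit.

With carboxy and the thioether both present, 4-(dimethylamino)phenyl in place of 4-chloro-3-nitrophenyl gives no change at the digits printed from compound 2 to compound 4 (within the scatter), so in this pair the aryl group on the double bond does not separate the two compounds.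

Whether the free carboxylic acid is needed at this position stays open, since a methyl ester, a primary amide or a tetrazole there is not among the compounds shown. Also open, from the compounds shown here alone, is how a sulfone behaves alongside the 4-chloro-3-nitrophenyl group.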